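A few compounds are considered here, and "the series" means these few. Any claim that something is new, unique, unknown or untested is made for them only; others in the source may bear on it.

Of the compounds shown here, three with a shared core have been tested in a functional assay on K562 cells (Homo sapiens) for antiproliferative activity, with a stated time of 72 h; on this read-out lower numbers stand for stronger inhibition and higher numbers for weaker inhibition. There, compound 1 `OC[C@H]1O[C@@H](n2cnc3c(NCc4ccccc4Cl)ncnc32)[C@H](O)[C@@H]1O` gives 64000 nM and compound 2 `OC[C@H]1O[C@@H](n2cnc3c(NCc4ccc(Cl)cc4)ncnc32)[C@H](O)[C@@H]1O` gives 218000 nM. Compound 3 `COc1cccc(CNc2ncnc3c2ncn3[C@@H]2O[C@H](CO)[C@@H](O)[C@H]2O)c1OC` has no exact number, only a limit of > 166000 nM. Compound 4 `OC[C@H]1O[C@@H](n2cnc3c(NCc4ccc(F)c(Cl)c4)ncnc32)[C@H](O)[C@@H]1O` carries 3-chloro-4-fluorophenyl in place of 2,3-dimethoxyphenyl on a saturated chain carbon bound to a nitrogen on an aromatic ring. Among the compounds with values here, two measured steps bear on this change. The first, an at least 2.5-fold higher number from compound 1 to compound 3 (0.41 log units; beyond the scatter), replaces 2-chlorophenyl with 2,3-dimethoxyphenyl. The second, a 3.4-fold higher number from compound 1 to compound 2 (0.53 log units; beyond the scatter), shows that chlorinated compounds can differ modestly from each other. The expected step, modest and towards a lower number, is an at least 1.5-fold lower number from compound 3 to compound 4 (0.17 log units; that floor lies within the scatter). For compound 4 the estimate is 110000 nM, with an expected range of 40000 nM to 280000 nM.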

Compound 4, half-maximal inhibitory concentration: 5500 nM
Estimate against measurement, compound 4: 20-fold (1.30 log units) above, and the stated range ends above it.
By their numbers in this assay, from the lowest: compound 4; then compound 1; then compound 2.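

On a saturated chain carbon bound to a nitrogen on an aromatic ring, 3-chloro-4-fluorophenyl gives the first large shift in this assay, with a 12-fold lower number from compound 1 to compound 4 (1.07 log units; beyond the scatter) and a 40-fold lower number from compound 2 to compound 4 (1.60 log units; beyond the scatter), whereas the chlorophenyl swap had been only modest. Against 2,3-dimethoxyphenyl, the change gives an at least 30-fold lower number from compound 3 to compound 4 (1.47 log units; beyond the scatter) as its step. That step is a floor, since compound 3 has only a limit: the limit of > 166000 nM in this assay, at which 1 of the 4 values shown sits.

From the compounds shown here alone, whether the chlorine or the fluorine of 3-chloro-4-fluorophenyl matters more remains open. So does the effect of a phenyl carrying an amine or a carboxylic acid at this place.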